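The source may hold more compounds than are shown below. What is called first, only, known or untested is meant among the compounds shown, and "the series" means these compounds.

Measured so far:
compound 1, `O=C(CSC(=S)N[C@H]1CCOC1=O)Nc1ccc(Cl)cc1`, 76900 nM
compound 2, `O=C(CSC(=S)N[C@H]1CCOC1=O)Nc1ccccc1`, 39700 nM
compound 3, `O=C(CSC(=S)N[C@H]1CCOC1=O)Nc1ccc(C(=O)/C=C/c2ccc(Cl)cc2)cc1`, 6900 nM

All three values come from a functional assay on MGC-803 cells (Homo sapiens) for cytotoxicity, read by MTT assay, with a stated time of 72 h; on this read-out lower numbers stand for stronger inhibition and higher numbers for weaker inhibition. Compound 1 and compound 2 share a core and differ by hydrogen in place of chloro on an aromatic carbon; the step of a 1.9-fold lower number from compound 1 to compound 2 (0.29 log units; within the scatter) is within the scatter, so the two are read as equal. Compound 3 carries a different core, and the difference between its core and that of compound 1 is not broken down here; its number is the lowest of the three, and the gaps to compound 2 and to compound 1 both lie beyond the scatter.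

Compound 4, `O=C(CSC(=S)N[C@H]1CCOC1=O)Nc1ccc(C(=O)/C=C/c2ccccc2)cc1`, is not yet measured. It differs from compound 3 by hydrogen in place of chloro on an aromatic carbon, the same change that separates compound 1 from compound 2, with the place described in the same words, though here the chlorophenyl sits in the ethenyl arm. Going by the values given here, the only precedent for this change is compound 1 to compound 2, which gave a 1.9-fold lower number from compound 1 to compound 2 (0.29 log units; within the scatter), so the expected step of a 1.0-fold higher number from compound 3 to compound 4 (0.01 log units; within the scatter) is again within the scatter. On that basis compound 4 is estimated at 7000 nM, with a range from 3000 nM to 16000 nM.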

Compound 4, half-maximal inhibitory concentration: 24800 nM
For compound 4 the middle estimate is 3.5-fold (0.55 log units) below the measured one; the whole stated range lies below it.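

In this assay, hydrogen in place of chloro does not behave as one transferable step across the two cores: the same change on two cores in this assay, a 1.9-fold lower number (0.29 log units; within the scatter) from compound 1 to compound 2 and a 3.6-fold higher number (0.56 log units; beyond the scatter) from compound 3 to compound 4, 7.0-fold (0.84 log units) apart, beyond the scatter of two such steps. On the core of compound 4, (2-phenylethenyl)carbonyl in place of hydrogen gives a 1.6-fold lower number from compound 2 to compound 4 (0.20 log units; within the scatter), and in place of chloro it gives a 3.1-fold lower number from compound 1 to compound 4 (0.49 log units; beyond the scatter), while loss of the chloro from the 2-(4-chlorophenyl)ethenyl arm gives a 3.6-fold higher number from compound 3 to compound 4 (0.56 log units; beyond the scatter). These results rest on two matched pairs: they show that the step seen on one core is a poor guide to the other, but not why the two cores differ or what the chloro would do on a third core.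

Going by these compounds, it remains open whether fluoro, bromo or methoxy at the same place on the phenyl ring of the 2-phenylethenyl arm would follow chloro. Also open, on these data alone, is whether the number from compound 3 would hold with an ethyl link in place of the ethenyl, or with a dimethylamino group in place of the chloro.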